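From Dichlorophenyl to Dimethoxyphenyl on a Shared Core

The source may hold more compounds than are shown below. What is called first, only, known or untested is meant among the compounds shown, and "the series" means these compounds.

Among the measured compounds shown here, in an ADME assay on MT4 cells (Homo sapiens) for cytotoxicity, read by MTT assay (on this read-out higher numbers stand for lower toxicity in this test and lower numbers for higher toxicity in this test), compound 1 `Cc1ccc(N(C(=O)c2ccc(F)cc2F)C(=S)OCCN2C(=O)c3ccccc3C2=O)cc1` gives 20000 nM and compound 2 `Cc1ccc(N(C(=O)c2ccc(Cl)c(Cl)c2)C(=S)OCCN2C(=O)c3ccccc3C2=O)cc1` gives 17000 nM, so compound 2 stands level with its only neighbour. Compound 3 `COc1cccc(OC)c1C(=O)N(C(=S)OCCN1C(=O)c2ccccc2C1=O)c1ccc(C)cc1` has 2,6-dimethoxyphenyl in place of 3,4-dichlorophenyl on a carbonyl carbon. For the measured compounds named here, the one measured step that bears on this swap at the same place is a 1.2-fold lower number from compound 1 to compound 2 (0.07 log units; within the scatter). One small step is thin evidence, but it points to no expected change beyond the scatter in this assay. The expected step is a 1.2-fold higher number from compound 2 to compound 3 (0.07 log units; within the scatter). For compound 3 the estimated value is 20000 nM, with an expected range of 9000 nM to 45000 nM.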

Compound 3, half-maximal cytotoxic concentration: 36000 nM
Estimate against measurement, compound 3: 1.8-fold (0.26 log units) below, and the stated range covers the measured number.
By their numbers in this assay, from the lowest: compounds 2, 1 and 3 (each within the scatter of the next, the first and the last beyond it).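

Among the compounds shown here, at this place on the carbonyl carbon, this assay now gives a first step that clears the scatter, a 2.1-fold higher number from compound 2 to compound 3 (0.33 log units; beyond the scatter). The same entering group set against 2,4-difluorophenyl stays within the scatter, a 1.8-fold higher number from compound 1 to compound 3 (0.26 log units; within the scatter), so 2,6-dimethoxyphenyl stands clearly apart only from 3,4-dichlorophenyl. Nothing available explains this difference. Still open, from the compounds shown here alone, is how an aromatic ring carrying an amine or a carboxylic acid would read here, and whether a phenyl ring with a single methoxy group would fall with the halogenated compounds or with compound 3.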